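Shifting a Methyl Group: From Compound 2 to Compound 3

The compounds below may be only part of what the source reports. "The series", "measured", "known", "first", "only" and "open" are said of these compounds alone.

Of the compounds shown here, two built on a shared core have been tested in a functional assay on MCF7 cells (Homo sapiens) for cytotoxicity, read by sulforhodamine B assay, with a stated time of 48 h; a higher number here means a weaker inhibitor, a lower number a stronger inhibitor. Compound 1 `CC1=C(/C=C/C(=O)/C=C/c2ccc(F)cc2)C(C)(C)CCC1` gives 6200 nM in this assay. Compound 2 `CC1=C(/C=C/C(=O)/C=C/c2ccc(C)cc2)C(C)(C)CCC1`, which carries a methyl in place of the fluoro on an aromatic carbon, gives 23800 nM. That exchange produced a 3.8-fold higher number from compound 1 to compound 2 (0.58 log units; beyond the scatter), so compound 2 stands with the highest of the two numbers, meaning it is the weaker inhibitor of this pair.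

Compound 3 `CC1=C(/C=C/C(=O)/C=C/c2ccccc2C)C(C)(C)CCC1` has not yet been measured. It differs from compound 2 by 2-methylphenyl in place of 4-methylphenyl on a double-bonded chain carbon bound to a double-bonded chain carbon; the two have the same atoms, joined differently. Going by the values given here, no measured step relocates a group from one aromatic carbon to another: the only step known, a 3.8-fold higher number from compound 1 to compound 2 (0.58 log units; beyond the scatter), swaps one group for another at a fixed place, so it offers no direct guide to this change. With nothing pointing clearly in either direction, the step of a 1.2-fold lower number from compound 2 to compound 3 (0.08 log units; within the scatter) is expected to stay within the scatter. Compound 3 is accordingly estimated at 20000 nM, with a plausible range from 7000 nM to 60000 nM.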

Compound 3, half-maximal inhibitory concentration: 44600 nM
Compound 3: middle estimate off by 2.2-fold (0.35 log units), on the low side, within the range that was stated.
By their numbers in this assay, from the lowest: compound 1; then compounds 2 and 3 (each within the scatter of the next).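

Moving the methyl group, with 2-methylphenyl in place of 4-methylphenyl, gives a 1.9-fold higher number from compound 2 to compound 3 (0.27 log units; within the scatter) in this assay, so this first relocation of a group on the aromatic ring produces no difference that can be told apart from ordinary repeat-to-repeat variation. Exchanging the fluoro-bearing ring directly, with 2-methylphenyl in place of 4-fluorophenyl, gives a 7.2-fold higher number from compound 1 to compound 3 (0.86 log units; beyond the scatter), which is beyond the scatter, so among these three compounds compound 1 has the lowest number, whichever of the two methylphenyl groups the comparison uses. No evidence is available on what lies behind these numbers.

The compounds shown leave open whether a fluoro group would behave like the methyl group when moved, since 2-fluorophenyl is not among them, and they give no view of what a hydroxyl, an amine or a carboxylic acid on the same aromatic ring would do. They also cannot tell whether the small step seen for the methyl group would hold for a larger group, such as a longer chain like propyl, placed on that ring.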